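Replacing a Hydroxyethyl Tail with a Cinnamoyl Hydrazide

A few compounds are considered here, and "the series" means these few. Any claim that something is new, unique, unknown or untested is made for them only; others in the source may bear on it.

Compound 1 `COc1cc(NC(C)CCCNC(=O)/C=C/c2ccccc2F)c2ncccc2c1` gives 3500 nM in an ADME assay on L6 cells (Rattus norvegicus) for cytotoxicity, read by resazurin assay, with a stated time of 70 h; on this read-out lower numbers stand for stronger inhibition and higher numbers for weaker inhibition. Compound 2 `COc1cc(NC(C)CCCNC(=O)NCCO)c2ncccc2c1` gives "not determined" (no result reported) in this assay, so it stands at no number at all. Compound 3 `COc1cc(NC(C)CCCNC(=O)NNC(=O)/C=C/c2ccccc2)c2ncccc2c1` differs from compound 2 in one place: ((2-phenylethenyl)carbonyl)amino in place of 2-hydroxyethyl on an amide-type nitrogen. Compound 2 carries no value, so the step to compound 3 cannot be sized or given a direction. For the measured compounds named here, the only anchor is compound 1, which shares the core and a phenyl-bearing amide with compound 3; compound 1 gives 3500 nM, and compound 3 is expected to roughly match that number, with no move beyond the scatter foreseen. Compound 3 is expected to give about 3500 nM, within 1500 nM to 9000 nM.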

Compound 3, half-maximal inhibitory concentration: 13900 nM
For compound 3 the middle estimate is 4.0-fold (0.60 log units) below the measured one; the whole stated range lies below it.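

For the compounds shown here, compound 2 has no number in this assay, so no step to compound 3 can be read. Going by these compounds, what replacing 2-hydroxyethyl with ((2-phenylethenyl)carbonyl)amino does to the read-out stays open. No evidence shown bears on this result.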